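The source may hold more compounds than are shown below. What is called first, only, known or untested is meant among the compounds shown, and "the series" means these compounds.

Measured in a functional assay on KB cells (Homo sapiens) for inhibition, with a stated time of 72 h; a lower number here means a stronger inhibitor, a higher number a weaker inhibitor:
compound 1 `COc1cc(C(=O)c2cccc3[nH]ccc23)cc(OC)c1OC`: 50.7 nM
compound 2 `COc1cc(C(=O)c2cccc3c2ccn3C)cc(OC)c1OC`: 22.1 nM
compound 3 `CCCn1ccc2cc(C(=O)c3cc(OC)c(OC)c(OC)c3)ccc21`: 1900 nM

Compound 3 gives 1900 nM, the highest number of the three, which makes it the weakest inhibitor here. Compound 4 `COc1cc(C(=O)c2ccc3c(ccn3CCC(=O)O)c2)cc(OC)c1OC` differs from it in one place: carboxy in place of methyl on a saturated chain carbon, two bonds along the chain from an aromatic nitrogen. In words, this is carboxy in place of methyl on a saturated chain carbon, two bonds along the chain from an aromatic nitrogen. For the measured compounds named here, only one measured step concerns a group on an aromatic nitrogen: a 2.3-fold lower number from compound 1 to compound 2 (0.36 log units; beyond the scatter). Going by the values given here, it was modest, and no measured compound carries a carboxy group, so it is only a loose guide. A modest move towards a higher number, meaning a weaker inhibitor, is expected, though with real uncertainty. The estimated step is a 3.2-fold higher number from compound 3 to compound 4 (0.50 log units; beyond the scatter). For compound 4 the estimated value is 6000 nM, with an expected range of 1500 nM to 30000 nM.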

Compound 4, half-maximal inhibitory concentration: > 10000 nM
Compound 4: a limit, no number (the forecaster's own chance of this, stated with the estimate: 30%); middle value at least 1.6-fold (0.22 log units) from the limit.
By their numbers in this assay, from the lowest: compound 2; then compound 1; then compound 3. At a limit, above all of these: compound 4.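

Compound 4 reaches only a limit of this assay and not a number: > 10000 nM is what stands for it. Going from propyl to 2-carboxyethyl on the aromatic nitrogen gives an at least 5.2-fold higher number from compound 3 to compound 4 (0.72 log units; beyond the scatter) and its true size stays unknown. For the compounds shown here, the only earlier step at an aromatic nitrogen was a 2.3-fold lower number from compound 1 to compound 2 (0.36 log units; beyond the scatter) and it went towards a lower number, so this is the first sign that a change there can cost activity.

As far as these compounds go, whether the carboxy group itself matters remains open. An amine or an alcohol at the same place, or a longer chain ending in a carboxylic acid, would help to settle this.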